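This account rests on a few compounds, and the source may have more. Where it says the series, first, only, none or still open, it means among the compounds named here.

Compound 1 `COc1cc(OC)c2sc(-c3ccc(N/C=C\C(=O)c4ccc(OC)c(O)c4)c(C)c3)nc2c1` and compound 2 `COc1ccc(C(=O)/C=C\Nc2ccc(-c3nc4cc(OC)c(OC)c(OC)c4s3)cc2C)cc1O` share one core and differ in a single spot. In a functional assay on HeLa cells (Homo sapiens) for antiproliferative activity, read by sulforhodamine B assay, with a stated time of 48 h (on this read-out higher numbers stand for weaker inhibition and lower numbers for stronger inhibition), compound 1 gives 16100 nM, and compound 2 gives 11400 nM. The change between them is methoxy in place of hydrogen on an aromatic carbon, and the step it made was a 1.4-fold lower number from compound 1 to compound 2 (0.15 log units; within the scatter). Compound 3 `COc1cc(OC)c2sc(-c3ccc(N/C=C\C(=O)c4cc(OC)c(OC)c(OC)c4Br)c(C)c3)nc2c1` is built on a different core; how the two cores differ is not broken down here. In this assay compound 3 gives 14700 nM, a number that sits within the scatter of both compound 1 and compound 2, so none of the three can be told apart by strength on these data.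

Compound 4 `COc1cc(C(=O)/C=C\Nc2ccc(-c3nc4cc(OC)c(OC)c(OC)c4s3)cc2C)c(Br)c(OC)c1OC` has not yet been measured. It comes from compound 3 by methoxy in place of hydrogen on an aromatic carbon. Within the data shown here, this is the same change as the one from compound 1 to compound 2: the group that enters is the same, and the place it enters is described in the same words. Because that earlier change gave a 1.4-fold lower number from compound 1 to compound 2 (0.15 log units; within the scatter), the expectation for this assay is that compound 4 will show a similarly small step, a 1.4-fold lower number from compound 3 to compound 4 (0.15 log units; within the scatter), from compound 3. Among the measured compounds shown here, on this basis compound 4 is expected to give about 10500 nM in this assay, with a likely range from 5000 nM to 22000 nM; this rests on the one earlier pair alone.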

Compound 4, half-maximal inhibitory concentration: 14300 nM
Estimate against measurement, compound 4: 1.4-fold (0.13 log units) below, and the stated range covers the measured number.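

In this assay the new step is a 1.0-fold lower number from compound 3 to compound 4 (0.01 log units; within the scatter) and so, on the core of compound 3 as on the core of compound 1, methoxy in place of hydrogen on an aromatic carbon moves the number by no more than repeated measurements of the same compound might. Set side by side, the two steps cannot be told apart, so on these two cores the change carries over in the sense that it stays too small to read each time: the same change on two cores in this assay, a 1.4-fold lower number (0.15 log units; within the scatter) from compound 1 to compound 2 and a 1.0-fold lower number (0.01 log units; within the scatter) from compound 3 to compound 4, 1.4-fold (0.14 log units) apart, within the scatter of two such steps. This does not show that methoxy makes these compounds stronger or weaker inhibitors, since neither step rises above the scatter, and two pairs with such small steps say nothing about how the change would behave on any further core.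

Still open, on these data alone, is whether another group at this place, such as an amine, a carboxylic acid or a longer chain like propoxy, would give a step beyond the scatter. Also open is whether methoxy would leave the number just as unmoved in other cell lines, or on a core beyond the two shown here.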